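This account rests on a few compounds, and the source may have more. Where it says the series, first, only, none or still open, it means among the compounds named here.

Of the compounds shown here, three sharing one core have been measured in a functional assay on HeLa cells (Homo sapiens) for inhibition, read by sulforhodamine B assay, with a stated time of 48 h; on this read-out higher numbers stand for weaker inhibition and lower numbers for stronger inhibition. Compound 1 `COC(=O)c1c[nH]c([C@@H](O)c2ccccc2)cc1=O` gives in this assay only a limit of the assay, > 50000 nM. Compound 2 `CC(C)CC(=O)NC(=O)c1c[nH]c([C@@H](O)c2ccccc2)cc1=O` likewise gives in this assay only a limit, > 50000 nM. Compound 3 `CC(=O)O[C@@H](c1ccccc1)c1cc(=O)c(C(N)=O)cn1CCO` also gives in this assay only a limit, > 50000 nM. Going by the values given here, the single one-point step among them, a step that the two limits leave unreadable from compound 1 to compound 2, is therefore not readable in size, since both of its ends sit at the limit of > 50000 nM in this assay, at which 3 of the 3 values shown sit. Compound 2 thus stands at the same limit as every other compound shown, and no ordering among them can be drawn.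

Compound 4 `CC(C)CC(=O)NC(=O)c1cn(CCO)c([C@@H](O)c2ccccc2)cc1=O` differs from compound 2 by 2-hydroxyethyl in place of hydrogen on an aromatic nitrogen. Among the compounds with values here, no measured step bears directly on this change. Within the data shown here, the only step measured is unreadable, and compound 3, which carries the same 2-hydroxyethyl on the aromatic nitrogen along with other differences, sits at the limit as well. For compound 4 the step that the limit leaves unreadable from compound 2 to compound 4 is expected to be none beyond the scatter. Compound 4 is accordingly estimated at 70000 nM, within 20000 nM to 250000 nM, and most probably the assay will again report only a limit for it.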

Compound 4, half-maximal inhibitory concentration: > 50000 nM
Compound 4 ended at the assay's limit; the forecaster's own chance of this, stated with the estimate: 85%; the middle value is on the limit's open side.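

In this assay compound 4 gives only a limit of the assay, > 50000 nM. Going by these compounds alone, no step from compound 2 to compound 4 can therefore be read in size, since both compounds sit at the same limit: the limit of > 50000 nM in this assay, at which 4 of the 4 values shown sit.

The compounds shown leave open whether any change on the shared core gives a measurable inhibition in these cells.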